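The source may report more compounds than this note shows. Statements on the series, on what has been measured and on what is new or still open speak of the compounds shown alone.

Measured compounds:
compound 1, `COc1ccc(/C=C/C(=O)NC(=O)c2ccccc2)cc1`, gives 5.61% in a functional assay, with a stated time of 30 min, tested at 1 mM; a lower number here means less inhibition, a higher number more inhibition at the concentration tested (going by the name of the read-out);
compound 2, `O=C(/C=C/c1ccc(O)c(Br)c1)NC(=O)c1ccccc1`, gives 17.3% in this assay.

Compound 2 holds the higher of the two numbers; its nearest neighbour, compound 1, sits lower by a gap beyond the usual scatter. The two differ in more than one place, so nothing more can be drawn from that pair than the two values themselves.

Compound 3, `O=C(/C=C/c1ccc(O)cc1)NC(=O)c1ccccc1`, has not yet been measured in this assay. It differs from compound 2 in one respect: hydrogen in place of bromo on an aromatic carbon. Since compound 3 keeps the hydroxy group of compound 2 and drops only the bromo, the step of a number 6.3 percentage points lower from compound 2 to compound 3 (within the scatter) is expected to be a small downward move, probably within the scatter. Compound 3 is therefore expected to give about 11% in this assay, in the range 0% to 25%.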

Compound 3, a percentage reported as inhibition, at one concentration (the size of the read-out at that concentration, not a potency): 4.89%
Compound 3: the middle estimate sits 6.1 percentage points above what was measured; the range from low to high includes it.
By their numbers in this assay, from the lowest: compounds 3 and 1 (each within the scatter of the next); then compound 2.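

In this assay, hydrogen in place of bromo on the aromatic carbon ortho to a hydroxy group gives a number 12.4 percentage points lower from compound 2 to compound 3 (beyond the scatter), so the higher number of compound 2 depends on the bromo at this position and is not carried by the hydroxy group alone. Hydrogen in place of methyl on the oxygen gives a number 0.7 percentage points lower from compound 1 to compound 3 (within the scatter), so that change on its own does not separate the two compounds. No measurement here explains what the bromo does at this position.

The compounds shown leave open whether chloro, methyl or a nitrile on this aromatic carbon would keep the number of compound 2 or fall back towards that of compound 3. They also do not tell whether bromo would give a similar step with a methyl group on the oxygen.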